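Swapping methoxy for methylamino on a quinone-like ring

The source may report more compounds than this note shows. Statements on the series, on what has been measured and on what is new or still open speak of the compounds shown alone.

- compound 1 `CC1=CCC[C@H]2[C@](C)(CC3=CC(=O)C(Sc4ccccc4)=CC3=O)[C@@H](C)CC[C@]12C`: 11200 nM
- compound 2 `COC1=CC(=O)C=C(C[C@]2(C)[C@@H](C)CC[C@]3(C)C(C)=CCC[C@@H]23)C1=O`: 5500 nM

In an ADME assay on PBMC cells (Homo sapiens) for inhibition, read by MTT assay (on this read-out lower numbers stand for stronger inhibition and higher numbers for weaker inhibition), compound 2 gives 5500 nM, the lower of the two numbers, and this gap to compound 1 at 11200 nM lies beyond the scatter. Compound 3 `CNC1=CC(=O)C=C(C[C@]2(C)[C@@H](C)CC[C@]3(C)C(C)=CCC[C@@H]23)C1=O` keeps the core of compound 2 but carries methylamino in place of methoxy on a double-bonded ring carbon. Among the compounds with values here, no measured pair shows this exchange, so the data offer only a weak guide. In this assay a modest move towards a higher number, meaning weaker inhibition, is expected, and it may not exceed the scatter. The expected change is a 1.5-fold higher number from compound 2 to compound 3 (0.16 log units; within the scatter). Compound 3 is estimated at 8000 nM, with an expected range from 2500 nM to 25000 nM.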

Compound 3, half-maximal inhibitory concentration: 4200 nM
Compound 3: the middle estimate sits 1.9-fold (0.28 log units) above what was measured; measured number inside the range.
By their numbers in this assay, from the lowest: compounds 3 and 2 (each within the scatter of the next); then compound 1.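

In this assay the exchange of methoxy for methylamino on this double-bonded ring carbon gives a 1.3-fold lower number from compound 2 to compound 3 (0.12 log units; within the scatter) and stays within the scatter, so the two compounds cannot be told apart on this read-out. The exchange brings in a hydrogen-bond donor where methoxy has none, and at this position, two ring bonds from the ring atom that bears the large group, this pair shows no difference the assay can resolve. Nothing in the data explains this result.

Going by these compounds, whether a bulkier amine on the same carbon, such as dimethylamino or a longer chain like butylamino, would also stay within the scatter of compound 2 remains open. One pair also cannot show whether the same exchange would give a similar step on another core.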